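Nitro Group Added to a Compound at the Assay Limit

The source may hold more compounds than are shown below. What is called first, only, known or untested is meant among the compounds shown, and "the series" means these compounds.

Measured compounds:
Compound 1, `COc1ccc(/C=N/NC(=S)NC(C)(C)[C@H]2CC=C(C)CC2)cc1`: in a functional assay on K562 cells (Homo sapiens) for inhibition, read by sulforhodamine B assay, with a stated time of 48 h (on this read-out lower numbers stand for stronger inhibition of growth and higher numbers for weaker inhibition of growth), compound 1 gives 1500 nM.
Compound 2, `CC1=CC[C@H](C(C)(C)NC(=S)N/N=C(\C)c2ccccc2)CC1`: in this assay compound 2 gives > 100000 nM.

Going by the values given here, the two measured compounds share a core but differ in several places at once, so no single step links them; their numbers simply show that compound 1 has a measured value while compound 2 does not. For compound 2 the entry is not a number but (the limit of > 100000 nM in this assay, at which 1 of the 2 values shown sits), meaning only that growth inhibition was too weak to be quantified in this assay.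

Compound 3, `CC1=CC[C@H](C(C)(C)NC(=S)N/N=C(\C)c2ccc([N+](=O)[O-])cc2)CC1`, follows from compound 2 by one change: nitro in place of hydrogen on an aromatic carbon. The new group sits on an aromatic carbon of a six-membered aromatic ring of carbon only, para to a large group. Among the compounds with values here, no measured pair here shows what such a change does in this assay, so the expectation rests on compound 2 alone. Starting from a limit, the step from compound 2 to compound 3 is expected to be an at least 1.6-fold lower number from compound 2 to compound 3 (0.22 log units; that floor lies within the scatter), at most modest and possibly none beyond the scatter. Compound 3 is therefore estimated at 60000 nM, with a range from 10000 nM to 300000 nM, and a real chance that only a limit is reported again.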

Compound 3, concentration for 50% growth inhibition: 83400 nM
The estimate for compound 3 lay 1.4-fold (0.14 log units) below the measured number, within the range that was stated.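

Compound 3 gives this position something compound 2 could not: a number. With nitro on an aromatic carbon, para to a large group, compound 3 gives 83400 nM in this assay, so the effect of a change at this place can now be compared against a real value. Even so, the change reads only as an at least 1.1-fold lower number from compound 2 to compound 3 (0.07 log units; that floor lies within the scatter), which means the compounds do not establish that nitro here does anything beyond ordinary variation between repeated measurements, and the true size of the step can be read only as a floor, since the starting point for compound 2 is a limit and not a number: the limit of > 100000 nM in this assay, at which 1 of the 3 values shown sits.

Going by these compounds, how much lower compound 3 truly lies than compound 2 stays open, and a single group cannot show whether this position matters in general or whether the result belongs to nitro alone. An amine or a carboxylic acid on the same aromatic carbon would be needed to tell whether other groups at this place give a lower number than compound 3 does.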